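The source may report more compounds than this note shows. Statements on the series, on what has been measured and on what is new or still open speak of the compounds shown alone.

In a functional assay on A549 cells (Homo sapiens) for antiproliferative activity, read by MTT assay, with a stated time of 72 h (a higher number here means a weaker inhibitor, a lower number a stronger inhibitor), compound 1 `COc1cc2ncnc(Nc3cccc(Br)c3)c2cc1OCCCCC(=O)Nc1ccc(S(N)(=O)=O)cc1` gives 14900 nM and compound 2 `COc1cc2ncnc(Nc3cccc(Cl)c3)c2cc1OCCCCC(=O)Nc1ccc(S(N)(=O)=O)cc1` gives 11200 nM; the step of a 1.3-fold lower number from compound 1 to compound 2 (0.12 log units; within the scatter) stays within the scatter. Compound 3 `COc1cc2ncnc(Nc3ccc(OC(F)(F)F)cc3)c2cc1OCCCCC(=O)Nc1ccc(S(N)(=O)=O)cc1` gives only > 40000 nM, which is a limit of the measurement rather than a number, so compound 3 stands at the weak end of what was resolved (the limit of > 40000 nM in this assay, at which 1 of the 3 values shown sits). Compound 4 `COc1ccccc1Nc1ncnc2cc(OC)c(OCCCCC(=O)Nc3ccc(S(N)(=O)=O)cc3)cc12` carries the change (2-methoxyphenyl in place of 4-(trifluoromethoxy)phenyl on a nitrogen on an aromatic ring). The measured steps that touch this position are an at least 2.6-fold higher number from compound 1 to compound 3 (0.42 log units; beyond the scatter) and an at least 3.5-fold higher number from compound 2 to compound 3 (0.55 log units; beyond the scatter), both weakening. Moving off the 4-(trifluoromethoxy)phenyl is therefore expected to give an at least 2.0-fold lower number from compound 3 to compound 4 (0.30 log units; that floor lies within the scatter), though no measured step shows 2-methoxyphenyl itself. Compound 4 is estimated at 20000 nM, within 7000 nM to 60000 nM.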

Compound 4, half-maximal inhibitory concentration: 24100 nM
Estimate against measurement, compound 4: 1.2-fold (0.08 log units) below; low and high end bracket the measured number.
By their numbers in this assay, from the lowest: compounds 2, 1 and 4 (each within the scatter of the next, the first and the last beyond it). At a limit, above all of these: compound 3.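

Replacing the halogen-bearing ring in this assay, 3-bromophenyl to 2-methoxyphenyl gives a 1.6-fold higher number from compound 1 to compound 4 (0.21 log units; within the scatter), whereas 3-chlorophenyl to 2-methoxyphenyl gives a 2.2-fold higher number from compound 2 to compound 4 (0.33 log units; beyond the scatter), so only the second step is a real loss. Leaving 4-(trifluoromethoxy)phenyl gives an at least 1.6-fold lower number from compound 3 to compound 4 (0.22 log units; that floor lies within the scatter), so a real gain is not established. Compound 3 is held only at a limit: the limit of > 40000 nM in this assay, at which 1 of the 4 values shown sits.

These steps change both the group and its place on the ring, so the two effects cannot be separated. As far as these compounds go, whether an amine or a carboxylic acid on this phenyl ring would give a lower number remains open.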